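A few compounds are considered here, and "the series" means these few. Any claim that something is new, unique, unknown or untested is made for them only; others in the source may bear on it.

Measured compounds in an assay on HEK293 cells for positive allosteric modulation of metabotropic glutamate receptor 2 (Rattus norvegicus), read by thallium flux, with a stated time of 2.5 min; on this read-out lower numbers stand for smaller maximal responses and higher numbers for larger maximal responses:

compound 1 `Cc1c(OCCCCOc2ccc(F)c(C(=O)O)c2)ccc(C(=O)CC2CCCC2)c1O` — 81%
compound 2 `COc1ccc(C(=O)O)cc1OCCCCOc1ccc(C(=O)CC2CCCC2)c(O)c1C` — 91.8%
compound 3 `Cc1c(OCCCCOc2ccc(C(=O)O)c(Cl)c2)ccc(C(=O)CC2CCCC2)c1O` — 80.8%

Within the data shown here, compound 1 is second highest of the three in this assay ; it is within the scatter of compound 3, as a number 0.2 percentage points lower from compound 1 to compound 3 (within the scatter) shows, and the only step beyond the scatter from it is a number 10.8 percentage points higher from compound 1 to compound 2 (beyond the scatter). The other measured step, a number 11 percentage points lower from compound 2 to compound 3 (beyond the scatter), likewise turns on the aryl group on the oxygen on a saturated carbon.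

Compound 4 `Cc1c(OCCCCOc2ccc(F)c(C(=O)O)c2)ccc(C(=O)C(C)C)c1O` is not yet measured. It differs from compound 1 elsewhere: isopropyl in place of cyclopentylmethyl on a carbonyl carbon. Among the measured compounds shown here, none of the three measured steps touches the carbonyl side of the shared core, so no measured step bears directly on this change. The measured steps give no basis for expecting a move beyond the scatter, but also no check on one, so the range is kept wide. Compound 4 is therefore expected to give about 78% in this assay, between 60% and 95%, which means an expected step of a number 3 percentage points lower from compound 1 to compound 4 (within the scatter).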

Compound 4, largest response reached (reported as percent of maximum), in percent of the reference or control that the assay uses: 74.1%
Estimate against measurement, compound 4: 3.9 percentage points above, and the stated range covers the measured number.
By their numbers in this assay, from the lowest: compounds 4, 3 and 1 (each within the scatter of the next); then compound 2.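

In this assay, among these compounds, the earlier steps all turned on the aryl group on the oxygen on a saturated carbon, whereas this change is the first view of the carbonyl side of the shared core: isopropyl in place of cyclopentylmethyl on a carbonyl carbon gives a number 6.9 percentage points lower from compound 1 to compound 4 (within the scatter). In this one pair, the five-membered ring of cyclopentylmethyl is therefore not needed to keep the maximal response within the scatter, and the carbonyl position tolerates the smaller, ring-free group. No measurement on hand accounts for this step.

As far as these compounds go, it remains open whether isopropyl behaves the same way alongside the 5-carboxy-2-methoxyphenyl group of compound 2. From the compounds shown here alone, it is also open how the response would change with a phenyl ring, an amine or a longer chain on the carbonyl carbon.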